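The source may report more compounds than this note shows. Statements on the series, on what has been measured and on what is new or still open speak of the compounds shown alone.

Of the compounds shown here, three sharing one core have been measured in a functional assay on KB cells (Homo sapiens) for cytotoxicity, read by sulforhodamine B assay; a lower number here means a stronger inhibitor, a higher number a weaker inhibitor. Compound 1 (`C=C1[C@@H](OC(C)=O)C[C@@H]2[C@](C)(CO[Si](C)(C)C(C)(C)C)[C@H](OC(C)=O)CC[C@@]2(C)[C@@H]1C[C@@H](Nc1ccc(Br)cc1)C1=CCOC1=O`) gives 5230 nM, compound 2 (`C=C1[C@@H](OC(C)=O)C[C@@H]2[C@](C)(CO[Si](C)(C)C(C)(C)C)[C@H](OC(C)=O)CC[C@@]2(C)[C@@H]1C[C@@H](Nc1ccccc1F)C1=CCOC1=O`) gives 4740 nM, and compound 3 (`C=C1[C@@H](OC(C)=O)C[C@@H]2[C@](C)(CO[Si](C)(C)C(C)(C)C)[C@H](OC(C)=O)CC[C@@]2(C)[C@@H]1C[C@@H](Nc1ccccc1C(=O)O)C1=CCOC1=O`) gives 6050 nM. Compound 3 thus stands level with the other two, its value lying within the scatter of both.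

The next compound, compound 4 (`C=C1[C@@H](OC(C)=O)C[C@@H]2[C@](C)(CO[Si](C)(C)C(C)(C)C)[C@H](OC(C)=O)CC[C@@]2(C)[C@@H]1C[C@@H](Nc1cccc(OC)c1)C1=CCOC1=O`), differs from compound 3 only in the group on the amine nitrogen: 3-methoxyphenyl in place of 2-carboxyphenyl on an amine nitrogen. In short, 3-methoxyphenyl takes the place of 2-carboxyphenyl. All three measured steps bear on this change, since each exchanges the group at that same nitrogen. They are a 1.1-fold lower number from compound 1 to compound 2 (0.04 log units; within the scatter), a 1.2-fold higher number from compound 1 to compound 3 (0.06 log units; within the scatter) and a 1.3-fold higher number from compound 2 to compound 3 (0.11 log units; within the scatter), and every one lies within the scatter. For the measured compounds named here, none of the measured compounds carries a methoxy group, so that group itself remains untested. Even so, the exchanges made so far have left the number in this assay unmoved, so no change beyond the scatter is expected here. The expected size of the step is a 1.2-fold lower number from compound 3 to compound 4 (0.07 log units; within the scatter). Compound 4 is estimated at 5200 nM, with an expected range from 2800 nM to 9500 nM.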

Compound 4, half-maximal inhibitory concentration: 45200 nM
For compound 4 the middle estimate is 8.7-fold (0.94 log units) below the measured one; the measured number lies above the stated range.
By their numbers in this assay, from the lowest: compounds 2, 1 and 3 (each within the scatter of the next); then compound 4.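

In this assay the group on the amine nitrogen proves able to move the number after all: 3-methoxyphenyl in place of 2-carboxyphenyl gives a 7.5-fold higher number from compound 3 to compound 4 (0.87 log units; beyond the scatter) in a step beyond the scatter, and the two other exchanges at this nitrogen give a 9.5-fold higher number from compound 2 to compound 4 (0.98 log units; beyond the scatter) and an 8.6-fold higher number from compound 1 to compound 4 (0.94 log units; beyond the scatter) in the same direction. The level values of compounds 1, 2 and 3 therefore describe only the 4-bromophenyl, 2-fluorophenyl and 2-carboxyphenyl groups and not the position as a whole, and among the four compounds the weaker number belongs to compound 4 alone. No information is at hand on what sets the 3-methoxyphenyl group apart from the other three and the steps give only the size and direction of the change.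

The compounds shown do not separate the methoxy group from the place it occupies on the phenyl ring, which a 2-methoxyphenyl or 4-methoxyphenyl group on the same nitrogen would address. Going by these compounds, it also stays open whether a 3-fluorophenyl, a 3-methylphenyl or an unsubstituted phenyl group would stand with compounds 1, 2 and 3 or with compound 4.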